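Halogenated Aryl Amides in a Cytotoxicity Series

The compounds below may be only part of what the source reports. "The series", "measured", "known", "first", "only" and "open" are said of these compounds alone.

Compound 1 `O=C(Nc1ccc2nc(NC(=O)C3CCCCC3)sc2c1)c1ccccc1F`: 0.14 ug/mL
Compound 2 `COc1ccc(C(=O)Nc2ccc3nc(NC(=O)C4CCCCC4)sc3c2)cc1`: 4.9 ug/mL

Both compounds were tested in a functional assay on WI-38 VA13 cells (Homo sapiens) for cytotoxicity; on this read-out lower numbers stand for an effect already at smaller amounts and higher numbers for an effect only at larger amounts of compound. Compound 1 gives 0.14 ug/mL, and compound 2 gives 4.9 ug/mL. Compound 2 thus holds the highest of the two numbers; its nearest neighbour is compound 1, and the change between them is a 35-fold higher number from compound 1 to compound 2 (1.54 log units; beyond the scatter).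

Compound 3 `O=C(Nc1ccc2nc(NC(=O)C3CCCCC3)sc2c1)c1ccc(Cl)cc1Cl` has not been measured in this assay. It differs from compound 2 in one place: 2,4-dichlorophenyl in place of 4-methoxyphenyl on a carbonyl carbon. Going by the values given here, only one measured step bears on this change, a 35-fold higher number from compound 1 to compound 2 (1.54 log units; beyond the scatter), which shows that exchanging the aryl group on this carbonyl carbon moves the number strongly. Because compound 1, carrying a halogenated ring, gives 0.14 ug/mL, compound 3 with its 2,4-dichlorophenyl is expected to return to a lower number than compound 2, though the size of that return is uncertain. The estimate for compound 3 is 0.6 ug/mL, ranging from 0.12 ug/mL to 3 ug/mL. This corresponds to an expected step of an 8.2-fold lower number from compound 2 to compound 3 (0.91 log units; beyond the scatter).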

Compound 3, half-maximal effective concentration: > 4 ug/mL
Compound 3 ended at the assay's limit; the forecaster's own chance of this, stated with the estimate: 5%; middle value at least 6.6-fold (0.82 log units) from the limit.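

In this assay compound 3 gives > 4 ug/mL, which is a limit of the assay and not a number. Carrying halogen on the ring is thus not enough to keep the low number of compound 1, since 2,4-dichlorophenyl in place of 2-fluorophenyl on this carbonyl carbon gives an at least 28-fold higher number from compound 1 to compound 3 (1.45 log units; beyond the scatter), and the earlier compounds could not separate one halogenated ring from another. The step from the 4-methoxyphenyl of compound 2 cannot be read, so these two groups cannot be ordered: the limit of > 4 ug/mL in this assay, at which 1 of the 3 values shown sits.

The compounds shown leave open whether the low number of compound 1 is particular to 2-fluorophenyl or would also be seen with plain phenyl or 4-fluorophenyl on this carbonyl carbon. They also leave open what an aryl ring bearing an amine or a carboxylic acid would give in this assay.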